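The source may hold more compounds than are shown below. What is called first, only, known or untested is meant among the compounds shown, and "the series" means these compounds.

Measured so far in an assay for binding affinity to Alpha-1A adrenergic receptor (Homo sapiens); on this read-out higher numbers stand for weaker inhibition and lower numbers for stronger inhibition:
- compound 1 `CN1CCC(Cn2nc(Cc3ccc(Cl)cc3)c3ccccc3c2=O)C1`: 100 nM
- compound 2 `CN1CCC[C@@H]1Cn1nc(CCc2ccccc2)c2ccccc2c1=O`: 200 nM

Compound 1 sits at one end of the two numbers shown, with compound 2 as its only neighbour; the gap between them lies within the usual scatter of this assay, so the two cannot be told apart on these data. Both share the same core and carry a basic nitrogen on the substituent attached to the aromatic nitrogen of that core.

Compound 3 `CN(C)CCCn1nc(Cc2ccc(Cl)cc2)c2ccccc2c1=O` is the next one to be measured. It differs from compound 1 in one place: 2-(dimethylamino)ethyl in place of 1-methylpyrrolidin-3-yl on a saturated chain carbon bound to an aromatic nitrogen. The ring is opened into a chain, but the basic nitrogen and the methyl groups on it remain, and the rest of the molecule is unchanged. Among the measured compounds shown here, no measured pair shows what such a ring-opening does here, so the step is unknown from the data. For the measured compounds named here, with two compounds close together and no step to lean on, a small shift is expected, if any, likely toward a weaker number; the expected step is a 2.0-fold higher number from compound 1 to compound 3 (0.30 log units; within the scatter). Compound 3 is therefore estimated at 200 nM in this assay, within a range of 60 nM to 700 nM.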

Compound 3, inhibition constant: 316 nM
Compound 3: the middle estimate sits 1.6-fold (0.20 log units) below what was measured, within the range that was stated.
By their numbers in this assay, from the lowest: compounds 1, 2 and 3 (each within the scatter of the next, the first and the last beyond it).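

In this assay, among the compounds shown here, the change on a saturated chain carbon bound to an aromatic nitrogen gives a 3.2-fold higher number from compound 1 to compound 3 (0.50 log units; beyond the scatter), the first step that can be read across a single difference. It shows that this position is not indifferent to the form of the substituent: 1-methylpyrrolidin-3-yl and 2-(dimethylamino)ethyl both keep a methylated amine nitrogen, yet opening the ring gives a modest loss, and compound 3 still reads 316 nM in this assay. Nothing measured here explains this step.

This single pair cannot separate the loss of the ring from the change in the amine itself, and it rests on the shared core with the chlorinated benzyl group of compound 1 and compound 3, so it may not hold for other groups on that core. Still open, from the compounds shown here alone, is how the read-out responds to a longer chain ending in the dimethylamino group, to a primary amine in its place, or to a carboxylic acid, which would replace the amine altogether.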